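The compounds below may be only part of what the source reports. "The series", "measured", "known", "first", "only" and "open" are said of these compounds alone.

Compound 1 `Cc1ccc2[nH]c(=O)c(CN(Cc3ccc(N(C)C)cc3)Cc3ccc(C(C)(C)C)cc3)cc2c1`, compound 2 `Cc1ccc2[nH]c(=O)c(CN(Cc3ccc(C(C)(C)C)cc3)C(C)c3ccc(N(C)C)c(Cl)c3)cc2c1` and compound 3 `CN(C)c1ccc(CN(Cc2ccc(C(C)(C)C)cc2)Cc2cc3cc(Br)ccc3[nH]c2=O)cc1` have been measured, while compound 4 `CC(c1ccc(N(C)C)c(Cl)c1)N(Cc1ccc(C(C)(C)C)cc1)Cc1cc2cc(Br)ccc2[nH]c1=O` has not. In a toxicity assay on MDCK cells (Canis lupus familiaris) for cytotoxicity, read by crystal violet staining, with a stated time of 48 h (on this read-out lower numbers stand for higher toxicity in this test and higher numbers for lower toxicity in this test), compound 1 reaches only the limit > 5000 nM. In this assay compound 2 gives 9800 nM. In this assay compound 3 also stops at the limit > 10000 nM. The change from compound 1 to compound 2 is 1-(3-chloro-4-(dimethylamino)phenyl)ethyl in place of 4-(dimethylamino)benzyl on an amine nitrogen, and its step that the limit leaves unreadable from compound 1 to compound 2 stays unreadable because compound 1 sits at the limit of > 5000 nM in this assay, at which 1 of the 3 values shown sits. The two cores differ by bromo in place of methyl on an aromatic carbon, with the step that the two limits leave unreadable from compound 1 to compound 3 unreadable because compound 3 sits at the limit of > 10000 nM in this assay, at which 1 of the 3 values shown sits. Compound 4 carries the same change from compound 3, (1-(3-chloro-4-(dimethylamino)phenyl)ethyl in place of 4-(dimethylamino)benzyl on an amine nitrogen). Compound 4 is expected to give 12000 nM in this assay, estimated between 5000 nM and 40000 nM. The expected step that the limit leaves unreadable from compound 3 to compound 4 rests on compound 2, which gives 9800 nM.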

Compound 4, half-maximal cytotoxic concentration: 6100 nM
Beside the measured number, compound 4's estimate is 2.0-fold (0.29 log units) above it; measured number inside the range.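

In this assay, placing 1-(3-chloro-4-(dimethylamino)phenyl)ethyl in place of 4-(dimethylamino)benzyl on the amine nitrogen of the bromo core gives an at least 1.6-fold lower number from compound 3 to compound 4 (0.21 log units; that floor lies within the scatter). With that group in place, bromo in place of methyl gives a 1.6-fold lower number from compound 2 to compound 4 (0.21 log units; within the scatter), so this pair does not separate the two cores. Whether the change carries from one core to the other remains unshown, and the steps from compound 1 cannot be read, because compound 1 stands at a limit: the limit of > 5000 nM in this assay, at which 1 of the 4 values shown sits.

The compounds shown leave open what the chlorine and the branched ethyl link each do alone, which a 3-chloro-4-(dimethylamino)benzyl group and a 1-(4-(dimethylamino)phenyl)ethyl group would separate. They also leave open a morpholine in place of the dimethylamino group.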